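Chloro to cyano on the shared core

The compounds below may be only part of what the source reports. "The series", "measured", "known", "first", "only" and "open" are said of these compounds alone.

For the measured compounds named here, in a functional assay on MT2 cells (Homo sapiens) for cytotoxicity, read by MTT assay (a lower number here means that less compound is tolerated, a higher number that more compound is tolerated), three compounds have numbers so far. Compound 1 (`N#Cc1ccc(Nc2nccs2)cc1OCc1ccco1`) gives 18000 nM, and compound 2 (`N#Cc1ccc(Nc2nccs2)cc1OCc1cccs1`) gives 4100 nM. Compound 3 (`Clc1ccc(Nc2nccs2)cc1OCc1ccsc1`) gives 38000 nM, the highest of the three, with its gaps to both others beyond the scatter.

Compound 4 (`N#Cc1ccc(Nc2nccs2)cc1OCc1ccsc1`) is not yet measured. Its difference from compound 3 is cyano in place of chloro on an aromatic carbon, para to a (1,3-thiazol-2-yl)amino group.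

Going by the values given here, no measured step covers this exchange directly. Among the compounds with values here, the only step available is a 4.4-fold lower number from compound 1 to compound 2 (0.64 log units; beyond the scatter), which replaces furan-2-yl with thiophen-2-yl, and both of its compounds already carry cyano. It therefore bears on the question only indirectly, by showing how far two cyano compounds can lie apart. Both lie below compound 3, but compound 3 differs from each of them in more than one place, so this comparison is loose. A moderate move to a lower number in this assay is expected, beyond the scatter but with wide uncertainty. The expected step is a 3.8-fold lower number from compound 3 to compound 4 (0.58 log units; beyond the scatter). For compound 4 the estimate is 10000 nM, within a range of 3500 nM to 28000 nM.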

Compound 4, half-maximal cytotoxic concentration: 1100 nM
For compound 4 the middle estimate is 9.1-fold (0.96 log units) above the measured one; measured number below the stated range.
By their numbers in this assay, from the lowest: compound 4; then compound 2; then compound 1; then compound 3.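

In this assay, for the compounds shown here, cyano in place of chloro on an aromatic carbon, para to a (1,3-thiazol-2-yl)amino group, gives a 35-fold lower number from compound 3 to compound 4 (1.54 log units; beyond the scatter) and so provides the first direct reading of this exchange, with thiophen-3-yl held constant on the saturated chain carbon bound to an oxygen. With cyano held constant, the choice of ring on that chain carbon also moves the number: thiophen-3-yl in place of thiophen-2-yl gives a 3.7-fold lower number from compound 2 to compound 4 (0.57 log units; beyond the scatter) and thiophen-3-yl in place of furan-2-yl gives a 16-fold lower number from compound 1 to compound 4 (1.21 log units; beyond the scatter) in the same assay. The exchange at the chloro position is therefore the largest single-place step in this set, although the ring on the chain is not a silent place either.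

Going by these compounds, whether chloro to cyano carries the same size with furan-2-yl or thiophen-2-yl on the chain stays open, as does the outcome with a methoxy group, an amine or a carboxylic acid at this aromatic carbon. Nothing available gives a reason for the size of these steps.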